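The source may report more compounds than this note shows. Statements on the series, on what has been measured and on what is new or still open speak of the compounds shown alone.

Compound 1 `CCc1nc(Cc2c[nH]cn2)c(CC)s1` and compound 2 `CCc1sc(C(C)C)nc1Cc1c[nH]cn1` share one core, while compound 3 `Cc1nc(C)c(Cc2c[nH]cn2)s1` has a core whose difference from that of compound 1 is not broken down here. In a functional assay on the whole organism (Abdomen) with Mus musculus as the target (on this read-out lower numbers stand for an effect already at smaller amounts and higher numbers for an effect only at larger amounts of compound), compound 1 gives 1.8 mg/kg, compound 2 gives 7.5 mg/kg and compound 3 gives 1 mg/kg. The change from compound 1 to compound 2 is methyl in place of hydrogen on a saturated chain carbon bound to an aromatic carbon and a saturated chain carbon; it made a 4.2-fold higher number from compound 1 to compound 2 (0.62 log units; beyond the scatter). Compound 4 `Cc1nc(C)c(C(C)c2c[nH]cn2)s1` has not yet been measured; it arises from compound 3 by methyl in place of hydrogen on a saturated chain carbon bound to two aromatic carbons. This is the same kind of change, though here the saturated chain carbon is bound to two aromatic carbons rather than to an aromatic carbon and a saturated chain carbon. Because the earlier step was a 4.2-fold higher number from compound 1 to compound 2 (0.62 log units; beyond the scatter), a step of about a 3.0-fold higher number from compound 3 to compound 4 (0.48 log units; beyond the scatter) is expected in this assay. Compound 4 is therefore estimated at 3 mg/kg in this assay, somewhere between 1.2 mg/kg and 8 mg/kg.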

Compound 4, dose for half-maximal effect: > 30 mg/kg
Compound 4: only a limit was reported (the forecaster's own chance of this, stated with the estimate: 5%); middle value at least 10-fold (1.00 log units) from the limit.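

In this assay, methyl in place of hydrogen gave an at least 30-fold higher number from compound 3 to compound 4 (1.47 log units; beyond the scatter), so the direction of the earlier step carried over to this core but its size did not: the same change on two cores in this assay, a 4.2-fold higher number (0.62 log units; beyond the scatter) from compound 1 to compound 2 and an at least 30-fold higher number (1.47 log units; beyond the scatter) from compound 3 to compound 4, at least 7.2-fold (0.85 log units) apart, beyond the scatter of two such steps

The value of compound 4 is only a limit of the assay, so the true size of its step stays unknown: the limit of > 30 mg/kg in this assay, at which 1 of the 4 values shown sits.

Within the data shown here, with one pair per core, and a saturated chain carbon bound to two aromatic carbons in only one pair, these data do not show whether the core or that carbon sets the difference.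

The compounds shown leave open what an ethyl or a hydroxyl group in place of that hydrogen would do on either core. They also leave open whether methyl on a third core would give a step closer to the smaller or the larger one.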